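Swapping bromine for fluorine on a sulfonyl-linked phenyl ring

The source may hold more compounds than are shown below. What is called first, only, known or untested is meant among the compounds shown, and "the series" means these compounds.

Of the compounds shown here, three have been measured so far in an assay on HeLa cells for displacement of a labelled ligand from 5-hydroxytryptamine receptor 6 (Homo sapiens) (on this read-out higher numbers stand for weaker inhibition and lower numbers for stronger inhibition), and they share a common core carrying a sulfonyl-linked phenyl ring with a single halogen on it. Compound 1 `CN1CCC(n2cc(S(=O)(=O)c3cccc(F)c3)c3cccnc32)C1` gives 1.4 nM. Compound 2 `O=S(=O)(c1cccc(Cl)c1)c1cn(C2CCCNC2)c2ncccc12` gives 1.3 nM. Compound 3 `O=S(=O)(c1cccc(Br)c1)c1cn(C2CCCNC2)c2ncccc12` gives 3.8 nM, which is the highest of the three numbers; compound 1 and compound 2 both sit beyond the scatter below it.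

The step from compound 3 to compound 4 `O=S(=O)(c1cccc(F)c1)c1cn(C2CCCNC2)c2ncccc12` changes one atom: fluoro in place of bromo on an aromatic carbon. Within the data shown here, only one measured step bears on this directly, the halogen swap within the same piperidine-bearing core, which read a 2.9-fold higher number from compound 2 to compound 3 (0.47 log units; beyond the scatter). Compound 1 also carries a fluorine on that phenyl ring, but its amine ring differs, so its value of 1.4 nM is only a hint rather than a clean comparison.

Given that chloro to bromo raised the number in the step from compound 2 to compound 3, and that the fluoro-bearing compound 1 shows the low value it does, the expected direction is a lower number, with a step of about a 2.5-fold lower number from compound 3 to compound 4 (0.40 log units; beyond the scatter). Compound 4 is therefore estimated at 1.5 nM, with a likely range from 0.7 nM to 3.5 nM.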

Compound 4, inhibition constant: 2.4 nM
Beside the measured number, compound 4's estimate is 1.6-fold (0.20 log units) below it, and the stated range covers the measured number.
By their numbers in this assay, from the lowest: compounds 2, 1, 4 and 3 (each within the scatter of the next, the first and the last beyond it).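

In this assay fluoro in place of bromo on this aromatic carbon gives a 1.6-fold lower number from compound 3 to compound 4 (0.20 log units; within the scatter) and fluoro in place of chloro gives a 1.8-fold higher number from compound 2 to compound 4 (0.27 log units; within the scatter) so neither swap to fluoro moves the number by more than ordinary repeat variation. Among these compounds, the halogens therefore do not form a clear series here: the only step among them beyond the scatter remains a 2.9-fold higher number from compound 2 to compound 3 (0.47 log units; beyond the scatter) while compound 4 lies within the scatter of both of those compounds. With the 3-fluorophenyl group held fixed, the change at the other end of the molecule gives a 1.7-fold higher number from compound 1 to compound 4 (0.23 log units; within the scatter) and this piperidin-3-yl in place of 1-methylpyrrolidin-3-yl on an aromatic nitrogen also stays within the scatter.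

The compounds shown carry only a halogen at this place on the phenyl ring, so they leave open how a methoxy group, a nitrile or an amine there would read in this binding measurement. Nothing available accounts for the gap between the chloro and bromo compounds or for fluoro falling within the scatter of both.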